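Hydroxymethyl in place of methoxy at two positions: notes

The source may hold more compounds than are shown below. What is called first, only, known or untested is meant among the compounds shown, and "the series" means these compounds.

Measured so far:
compound 1 `COc1cccc(CNc2cc(C)nc3ccc(OC)cc23)c1` — 9700 nM
compound 2 `COc1ccc2nc(C)cc(NCc3ccccc3OC)c2c1` — 25200 nM
compound 3 `COc1ccc2nc(C)cc(NCc3cccc(CO)c3)c2c1` — 17100 nM

In a functional assay on MCF-10A cells (Homo sapiens) for antiproliferative activity, with a stated time of 48 h (on this read-out lower numbers stand for an effect already at smaller amounts and higher numbers for an effect only at larger amounts of compound), compound 1 gives 9700 nM. In this assay compound 2 gives 25200 nM, the highest of the three numbers, and compound 3 gives 17100 nM. Compound 1 and compound 2 differ in more than one place; the difference between the two cores is not broken down here.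

Compound 3 carries hydroxymethyl in place of methoxy on an aromatic carbon relative to compound 1. This made a 1.8-fold higher number from compound 1 to compound 3 (0.25 log units; within the scatter).

Compound 4 `COc1ccc2nc(C)cc(NCc3ccccc3CO)c2c1` is not yet measured. It carries hydroxymethyl in place of methoxy on an aromatic carbon relative to compound 2. The surroundings are not the same word for word: in compound 3 the group sits meta to a large group, in compound 4 ortho to a large group, so this is the same kind of change, not the same one.

A step of about a 1.4-fold higher number from compound 2 to compound 4 (0.15 log units; within the scatter) is expected in this assay because a 1.8-fold higher number from compound 1 to compound 3 (0.25 log units; within the scatter) followed the same kind of change. Compound 4 is expected at 36000 nM, between 15000 nM and 85000 nM.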

Compound 4, half-maximal effective concentration: 22900 nM
Compound 4: the middle estimate sits 1.6-fold (0.20 log units) above what was measured, and the stated range covers the measured number.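

In this assay, hydroxymethyl in place of methoxy on an aromatic carbon, ortho to a large group, gives a 1.1-fold lower number from compound 2 to compound 4 (0.04 log units; within the scatter). Set beside the earlier step, the result gives no sign that the outcome of this change depends on which of the two cores carries it: the same change on two cores in this assay, a 1.8-fold higher number (0.25 log units; within the scatter) from compound 1 to compound 3 and a 1.1-fold lower number (0.04 log units; within the scatter) from compound 2 to compound 4, 1.9-fold (0.29 log units) apart, within the scatter of two such steps. This does not show that the change is neutral in general or that it will carry over to further cores: neither step lies beyond the scatter, and two pairs support only a statement about these four compounds.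

The compounds shown leave open whether a group other than methoxy or hydroxymethyl at these places, such as an amine, a carboxylic acid or a longer chain, would move the number beyond the scatter. Also open, on these data alone, is whether the two steps would still agree in any read-out other than this assay.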